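This account rests on a few compounds, and the source may have more. Where it says the series, first, only, none or still open, it means among the compounds named here.

The measured compounds:

Compound 1, `COc1ccc(C(=O)NC(CCN(C)C)c2ccc(Cl)cc2)cc1`, gives 162% in an assay on NIH3T3 cells with Urotensin-2 receptor (Homo sapiens) as the target; on this read-out higher numbers stand for larger maximal responses and lower numbers for smaller maximal responses.
Compound 2, `CN(C)CCC(NC(=O)c1ccc(C(F)(F)F)cc1)c1ccc(Cl)cc1`, gives 115% in this assay.
Compound 3, `COc1ccc(NC(=O)OC(CCN(C)C)c2ccc(Cl)cc2)cc1`, gives 170% in this assay.

Compound 3 and compound 1 lie within the usual scatter of each other, while compound 2 sits well below both. Compound 4, `CN(C)CCC(OC(=O)Nc1ccc(C(F)(F)F)cc1)c1ccc(Cl)cc1`, has not yet been measured. Compound 4 is derived from compound 3 by one change, (trifluoromethyl in place of methoxy on an aromatic carbon). The same change has been made once before among these compounds, from compound 1 to compound 2, where it is trifluoromethyl in place of methoxy on an aromatic carbon and produced the step of a number 47 percentage points lower from compound 1 to compound 2 (beyond the scatter). The cores of compound 1 and compound 3 are not the same; the difference between the two cores is not broken down here. The question is whether the change repeats its effect on the core of compound 3. Since that step between compound 1 and compound 2 was a number 47 percentage points lower from compound 1 to compound 2 (beyond the scatter), a drop of similar size is expected in this assay for compound 4, a number 45 percentage points lower from compound 3 to compound 4 (beyond the scatter), though the different core leaves room for it to be smaller or larger. The estimate for compound 4 in this assay is 125%, expected to fall between 95% and 155%.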

Compound 4, largest response reached (reported as efficacy), in percent of the reference or control that the assay uses: 94%
The estimate for compound 4 lay 31 percentage points above the measured number; the whole stated range lies above it.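

In this assay, trifluoromethyl in place of methoxy on an aromatic carbon again gave a lower number, a number 76 percentage points lower from compound 3 to compound 4 (beyond the scatter). The direction of the step carried over from one core to the other, but its size did not: the same change on two cores in this assay, a number 47 percentage points lower (beyond the scatter) from compound 1 to compound 2 and a number 76 percentage points lower (beyond the scatter) from compound 3 to compound 4, 29 percentage points apart, beyond the scatter of two such steps. This shows that, in these two pairs, the direction of the change held while its size depended on the core it was made on; it does not show which feature of the cores accounts for the gap, and two pairs give no rule for the size of the step on any further core.

The compounds shown leave open whether the lower maximal response is specific to trifluoromethyl or would also follow from another replacement for methoxy at that carbon, such as a nitrile or a methyl group. They also leave open whether the step would keep its direction if the dimethylamino group were replaced by a pyrrolidine ring.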